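The source may hold more compounds than are shown below. What is called first, only, known or untested is meant among the compounds shown, and "the series" means these compounds.

Compound 3 `O=C(CN1CCN(c2cc3c(cc2F)c(=O)c(C(=O)O)cn3C2CC2)CC1)Nc1ccc(C(=O)/C=C/c2cccc([N+](=O)[O-])c2)cc1` stands lowest of the three measured compounds in a physicochemical assay for lipophilicity, using the shake flask method, in phosphate buffer, measured as octanol-water partition, with a stated time of 5 h (a lower number here means a more polar compound, a higher number a more lipophilic compound), where compound 3 gives -0.0812. Compound 1 `O=C(CN1CCN(c2cc3c(cc2F)c(=O)c(C(=O)O)cn3C2CC2)CC1)Nc1ccc(C(=O)/C=C/c2ccccc2)cc1` gives 1.29 in this assay, and compound 2 `O=C(CN1CCN(c2cc3c(cc2F)c(=O)c(C(=O)O)cn3C2CC2)CC1)Nc1ccc(C(=O)/C=C/c2ccccc2Cl)cc1` gives 1.29; between these two, no change at the digits printed from compound 1 to compound 2 (within the scatter). Both steps into compound 3 are large: a number 1.37 log units lower from compound 1 to compound 3 (beyond the scatter) and a number 1.37 log units lower from compound 2 to compound 3 (beyond the scatter). Compound 4 `Cc1ccc(/C=C/C(=O)c2ccc(NC(=O)CN3CCN(c4cc5c(cc4F)c(=O)c(C(=O)O)cn5C4CC4)CC3)cc2)c(C)c1` differs from compound 3 by 2,4-dimethylphenyl in place of 3-nitrophenyl on a double-bonded chain carbon bound to a double-bonded chain carbon. Within the data shown here, the measured steps cover this change only in part: the nitro group that leaves is the one whose arrival produced the large fall, while no measured step shows what the two methyl groups contribute, and the chloro step gave no change beyond the scatter. Compound 4 is therefore expected to regain roughly the fall seen in a number 1.37 log units lower from compound 1 to compound 3 (beyond the scatter), that is to rise by a number 1.58 log units higher from compound 3 to compound 4 (beyond the scatter) in this assay. The estimate for compound 4 is 1.5, with a range from 0.9 to 2.1.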

Compound 4, partition coefficient: 1.47
Estimate against measurement, compound 4: 0.03 log units above; the range from low to high includes it.
By their numbers in this assay, from the lowest: compound 3; then compounds 1, 2 and 4 (each within the scatter of the next).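

In this assay, placing 2,4-dimethylphenyl where 3-nitrophenyl stood gives a number 1.55 log units higher from compound 3 to compound 4 (beyond the scatter), so a single exchange on this double-bonded chain carbon undoes the whole of the earlier fall. Set against phenyl the same group gives a number 0.18 log units higher from compound 1 to compound 4 (within the scatter), and set against 2-chlorophenyl it gives a number 0.18 log units higher from compound 2 to compound 4 (within the scatter), so of the four aryl groups seen at this position only 3-nitrophenyl stands apart, and the two methyl groups, like the chloro group, leave no mark beyond the scatter. Nothing available explains this result.

The compounds shown leave open whether an amine or a carboxylic acid on this phenyl ring would bring the number down as far as the nitro group does, and whether the nitro group would do so at another place on the ring. Also open, on these data alone, is whether a longer chain in place of the two methyl groups would move the number beyond the scatter.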